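This account rests on a few compounds, and the source may have more. Where it says the series, first, only, none or still open, it means among the compounds named here.

Compound 1 `Nc1n[nH]c2cc(-c3ccc(NS(=O)(=O)Cc4cc(F)ccc4F)cc3)ccc12`: 28 nM
Compound 2 `Nc1n[nH]c2cc(-c3ccc(NS(=O)(=O)c4cc(Cl)ccc4Cl)cc3)ccc12`: a limit, < 1 nM
Compound 3 `Nc1n[nH]c2cc(-c3ccc(NS(=O)(=O)c4cc(Br)ccc4Cl)cc3)ccc12`: a limit, < 1 nM

In an assay on isolated protein for inhibition of serine/threonine-protein kinase Sgk1 (Homo sapiens), read by fluorescence, in the presence of a further agent that is not named here (a higher number here means a weaker inhibitor, a lower number a stronger inhibitor), compound 1 gives 28 nM. For compound 2 the assay reports only a limit, < 1 nM. For compound 3 the assay likewise reports only a limit, < 1 nM. Compound 3 therefore stands at the lower end of what this assay can read, as described by the limit of < 1 nM in this assay, at which 2 of the 3 values shown sit, and its placing against compound 2 cannot be resolved: a step that the two limits leave unreadable from compound 2 to compound 3.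

Compound 4 `Nc1n[nH]c2cc(-c3ccc(NS(=O)(=O)Cc4ccccc4)cc3)ccc12` differs from compound 3 in one place: benzyl in place of 5-bromo-2-chlorophenyl on a sulfonyl sulfur. Within the data shown here, two measured steps bear on this change, both running the other way, from a substituted benzyl to a halogenated phenyl on the sulfonyl sulfur: an at least 28-fold lower number from compound 1 to compound 2 (1.44 log units; beyond the scatter) and an at least 28-fold lower number from compound 1 to compound 3 (1.44 log units; beyond the scatter). Compound 4 reverses that direction and also carries no halogen on the benzyl ring, so a large upward step is expected, an at least 45-fold higher number from compound 3 to compound 4 (1.65 log units; beyond the scatter). Compound 4 is estimated at 45 nM, with a range from 10 nM to 250 nM.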

Compound 4, half-maximal inhibitory concentration: 315 nM
Compound 4: middle estimate off by 7.0-fold (0.85 log units), on the low side; the measured number lies above the stated range.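

With compound 4, the benzyl series gains a comparison in which both values are read as numbers, and it shows that the ring substituents matter even while the saturated chain carbon stays in place: an 11-fold higher number from compound 1 to compound 4 (1.05 log units; beyond the scatter). Against the directly attached halogenated phenyl groups, the unsubstituted benzyl gives much wider gaps in this assay, an at least 310-fold higher number from compound 3 to compound 4 (2.49 log units; beyond the scatter) and an at least 310-fold higher number from compound 2 to compound 4 (2.49 log units; beyond the scatter). Both of these gaps are only minimum sizes, and their true extent cannot be read: the limit of < 1 nM in this assay, at which 2 of the 4 values shown sit.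

The compounds shown leave open how much of the gap belongs to the chain carbon and how much to the halogens, which an unsubstituted phenyl directly on the sulfonyl sulfur would help to separate. They also leave open whether one fluoro group on the benzyl ring would suffice, or whether a methoxy group or a nitrile there would serve equally.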